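Methoxy for bromo on the aromatic carbon: compound 3

The source may report more compounds than this note shows. Statements on the series, on what has been measured and on what is new or still open speak of the compounds shown alone.

Within the data shown here, compound 2 `CC1(C)[C@H]2CC[C@]1(C)N(Cc1cn(-c3ccc(Br)cc3)nn1)C(=O)C2` gives 80 nM in a functional assay on A549 cells (Homo sapiens) for inhibition, read by MTT assay, with a stated time of 24 h (on this read-out lower numbers stand for stronger inhibition and higher numbers for weaker inhibition), the lowest of the two numbers so far; the nearest is compound 1 `CC1(C)[C@H]2CC[C@]1(C)N(Cc1cn(-c3ccc(C#N)cc3)nn1)C(=O)C2`, which gives 140 nM, and the step of a 1.8-fold lower number from compound 1 to compound 2 (0.24 log units; within the scatter) lies within the scatter, so the two cannot be ordered. Compound 3 `COc1ccc(-n2cc(CN3C(=O)C[C@@H]4CC[C@@]3(C)C4(C)C)nn2)cc1` carries the change (methoxy in place of bromo on an aromatic carbon). Among the measured compounds shown here, no measured step bears directly on this exchange: the only step, from cyano to bromo, was itself within the scatter, and nothing covers methoxy. On that basis no step beyond the scatter is expected for compound 3 in either direction, and the estimate is set near the existing pair with a wide range. Compound 3 is expected to give 120 nM, between 40 nM and 400 nM, corresponding to an expected step of a 1.5-fold higher number from compound 2 to compound 3 (0.18 log units; within the scatter).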

Compound 3, half-maximal inhibitory concentration: 50 nM
Compound 3: the middle estimate sits 2.4-fold (0.38 log units) above what was measured; the range from low to high includes it.
By their numbers in this assay, from the lowest: compounds 3, 2 and 1 (each within the scatter of the next, the first and the last beyond it).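

In this assay methoxy in place of bromo gives a 1.6-fold lower number from compound 2 to compound 3 (0.20 log units; within the scatter) and so leaves 4-bromophenyl and 4-methoxyphenyl unordered at this position. Methoxy in place of cyano gives a 2.8-fold lower number from compound 1 to compound 3 (0.45 log units; beyond the scatter) and is the first step in the series to clear the scatter, showing that the group on this aromatic carbon can shift the number modestly, although bromo cannot be separated from either of the other two. No measurement at hand accounts for these numbers.

From the compounds shown here alone, the three compounds vary only in cyano, bromo and methoxy at this one place, so how an amine, a carboxylic acid or a longer chain such as ethoxy would read there remains open. Going by these compounds, whether the same order would hold on a changed core also remains open.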